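A halogen swap on a compound at the limit

The source may report more compounds than this note shows. Statements on the series, on what has been measured and on what is new or still open speak of the compounds shown alone.

In a functional assay on NCI-H460 cells (Homo sapiens) for antiproliferative activity, read by MTT assay, with a stated time of 48 h (a higher number here means a weaker inhibitor, a lower number a stronger inhibitor), compound 1 `CCCCCC1(O)C(=O)Nc2ccc(Nc3ccc(F)cc3)cc21` gives > 100000 nM, which is a limit and not a number. Compound 3 `CCCCCC1(O)C(=O)Nc2ccc(Nc3ccc(Cl)cc3)cc21` keeps the same chain and differs only on the aromatic ring, with chloro in place of fluoro on an aromatic carbon, para to a large group: chloro in place of fluoro on an aromatic carbon. For the measured compounds named here, only one measured step starts from compound 1, an at least 5.9-fold lower number from compound 1 to compound 2 (0.77 log units; beyond the scatter), and it lies on the chain: isopropyl in place of propyl on a saturated chain carbon. With that change, compound 2 `CC(C)CCC1(O)C(=O)Nc2ccc(Nc3ccc(F)cc3)cc21` reads 16800 nM. This shows that a number can be reached in this series, but it says nothing directly about the halogen. Only a small move toward a lower number is therefore expected, an estimated at least 1.6-fold lower number from compound 1 to compound 3 (0.22 log units; that floor lies within the scatter), and the result may again be a limit. Compound 3 is estimated at 60000 nM, with an expected range from 15000 nM to 150000 nM.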

Compound 3, half-maximal inhibitory concentration: 40800 nM
Beside the measured number, compound 3's estimate is 1.5-fold (0.17 log units) above it; measured number inside the range.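

In this assay, chloro in place of fluoro on an aromatic carbon gives an at least 2.4-fold lower number from compound 1 to compound 3 (0.38 log units; beyond the scatter), so the chain is no longer the only place in this series where a change leads from the limit to a number. From the compounds shown here alone, the value of compound 1 is a limit and not a number, so only a floor can be read for this step and its true size stays unknown: the limit of > 100000 nM in this assay, at which 1 of the 3 values shown sits. Compound 3 and compound 2 differ in two places, so this result does not rank the halogen change against the chain change.

Going by these compounds, it remains open whether bromo or trifluoromethyl at this same place would lower the number further. The compounds shown also leave open what chloro would do on the isopropyl-bearing chain of compound 2.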